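The source may report more compounds than this note shows. Statements on the series, on what has been measured and on what is new or still open speak of the compounds shown alone.

Compound 1 `CC(C)N1C(=O)COc2ccc(-c3cnc(Cl)c(NS(=O)(=O)c4ccc(F)cc4)c3)cc21` is the reference point here. Within the data shown here, in a functional assay on A549 cells (Homo sapiens) for antiproliferative activity, read by MTT assay, with a stated time of 72 h (on this read-out lower numbers stand for stronger inhibition and higher numbers for weaker inhibition), compound 1 gives 5100 nM, the lowest of the two numbers measured so far. Among the measured compounds shown here, its only measured neighbour is compound 2 `COc1ccc(N2C(=O)COc3ccc(-c4cnc(Cl)c(NS(=O)(=O)c5ccc(F)cc5)c4)cc32)cc1`, which in this assay gives 30400 nM; the step of a 6.0-fold higher number from compound 1 to compound 2 (0.78 log units; beyond the scatter) comes from exchanging the group on the amide-type nitrogen in the ring, not from any part of the aromatic ring carrying the chloro.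

Compound 3 `COc1ncc(-c2ccc3c(c2)N(C(C)C)C(=O)CO3)cc1NS(=O)(=O)c1ccc(F)cc1` differs from compound 1 in exactly one place: methoxy in place of chloro on an aromatic carbon. For the measured compounds named here, no measured step touches this position, so the one step available, a 6.0-fold higher number from compound 1 to compound 2 (0.78 log units; beyond the scatter), gives no direct guide to the size or direction of the change. The chloro is exchanged for a small group of similar size, and the rest of the molecule is unchanged.

Compound 3 is therefore expected to give about 5500 nM in this assay, within a range of 1500 nM to 20000 nM. This estimate means a step of a 1.1-fold higher number from compound 1 to compound 3 (0.03 log units; within the scatter), which is expected to stay within the scatter.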

Compound 3, half-maximal inhibitory concentration: 4920 nM
Beside the measured number, compound 3's estimate is 1.1-fold (0.05 log units) above it, within the range that was stated.
By their numbers in this assay, from the lowest: compounds 3 and 1 (each within the scatter of the next); then compound 2.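

In this assay, methoxy in place of chloro on an aromatic carbon next to the ring nitrogen gives a 1.0-fold lower number from compound 1 to compound 3 (0.02 log units; within the scatter), so the two groups cannot be told apart at this position, although methoxy carries a hydrogen-bond acceptor that chloro lacks. The chloro is therefore not required for compound 3 to keep the level of compound 1, and this exchange contrasts with the exchange on the amide-type nitrogen, which gives a 6.0-fold higher number from compound 1 to compound 2 (0.78 log units; beyond the scatter). No supporting measurement bears on why chloro and methoxy read alike here.

The compounds shown leave open whether an amine, a hydroxyl or a longer chain such as ethoxy would read the same at this position. They also leave open whether methoxy and chloro would still read alike with 4-methoxyphenyl in place of isopropyl on the amide-type nitrogen.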